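The compounds below may be only part of what the source reports. "The series", "measured", "known", "first", "only" and "open" are said of these compounds alone.

Of the compounds shown here, three built on one shared core have been tested in a functional assay on KYSE-520 cells for antiproliferative activity against KYSE-520 cell line (Homo sapiens), read by CellTiter-Glo, with a stated time of 24 h; on this read-out higher numbers stand for weaker inhibition and lower numbers for stronger inhibition. Compound 1 `CNc1nccc(-c2n[nH]c3nc(N4CCC5(CC4)CO[C@@H](C)[C@H]5N)n(C)c(=O)c23)c1Cl` gives 370 nM. Compound 2 `C[C@@H]1OCC2(CCN(c3nc4[nH]nc(-c5ccnc(NC6CCC6)c5Cl)c4c(=O)n3C)CC2)[C@@H]1N` gives 380 nM; the change, cyclobutyl in place of methyl on a nitrogen on an aromatic ring, produced a 1.0-fold higher number from compound 1 to compound 2 (0.01 log units; within the scatter). Compound 3 `C[C@@H]1OCC2(CCN(c3nc4[nH]nc(Sc5ccnc(N)c5Cl)c4c(=O)n3C)CC2)[C@@H]1N` gives 720 nM; the change from compound 1, (2-amino-3-chloropyridin-4-yl)sulfanyl in place of 3-chloro-2-(methylamino)pyridin-4-yl on an aromatic carbon, produced a 1.9-fold higher number from compound 1 to compound 3 (0.29 log units; within the scatter). Compound 3 is thus separated from compound 1 and from compound 2 only by gaps of the size that repeated measurements of a single compound show, so the three numbers cannot be told apart with confidence.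

Compound 4 `Cc1nc(N)ccc1-c1n[nH]c2nc(N3CCC4(CC3)CO[C@@H](C)[C@H]4N)n(C)c(=O)c12` has not yet been measured in this assay. Its difference from compound 3 is 6-amino-2-methylpyridin-3-yl in place of (2-amino-3-chloropyridin-4-yl)sulfanyl on an aromatic carbon. Among the measured compounds shown here, the only measured step that touches this part of the molecule is a 1.9-fold higher number from compound 1 to compound 3 (0.29 log units; within the scatter), in which the sulfanyl link arrived together with a changed amino group and the number moved little. For the measured compounds named here, compound 4 removes that sulfanyl link but brings a differently substituted aminopyridine, for which there is no measured precedent here. The step is therefore expected to be a 1.8-fold lower number from compound 3 to compound 4 (0.26 log units; within the scatter), at the edge of the scatter. Compound 4 is estimated to give about 400 nM, with a likely range from 120 nM to 1500 nM.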

Compound 4, half-maximal inhibitory concentration: 660 nM
For compound 4 the middle estimate is 1.7-fold (0.22 log units) below the measured one; the range from low to high includes it.
By their numbers in this assay, from the lowest: compounds 1, 2, 4 and 3 (each within the scatter of the next).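

Swapping the (2-amino-3-chloropyridin-4-yl)sulfanyl group for 6-amino-2-methylpyridin-3-yl on this aromatic carbon gives a 1.1-fold lower number from compound 3 to compound 4 (0.04 log units; within the scatter) in this assay, and swapping the 3-chloro-2-(methylamino)pyridin-4-yl group of compound 1 for the same 6-amino-2-methylpyridin-3-yl gives a 1.8-fold higher number from compound 1 to compound 4 (0.25 log units; within the scatter). The earlier compounds shown here had varied only a chloropyridine at this position; compound 4 shows that a pyridine with a methyl group instead of a chlorine, joined without the sulfur, also gives a number that cannot be told apart from those of compound 1 and compound 3. Among these compounds, then, neither the sulfur link nor the chlorine separates one number from another, and nothing measured here offers a reason for this sameness.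

Among the compounds shown here, since every step so far stays within the scatter, no group at this position has yet been seen to move the read-out. A plain phenyl ring with no amino group, a pyridine carrying a hydroxyl group in place of the amine, or a short alkyl chain in place of the ring could show how much of the aromatic group this position actually needs.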